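Chain extension on the epimeric series: compound 3 to compound 4

The compounds below may be only part of what the source reports. "The series", "measured", "known", "first", "only" and "open" are said of these compounds alone.

Measured in an ADME assay on THP-1 cells (Homo sapiens) for cytotoxicity, read by MTT assay, with a stated time of 72 h; a higher number here means that more compound is needed for the effect, a lower number that less compound is needed:
compound 1 `O=C(CCC(F)(F)C(F)(F)C(F)(F)C(F)(F)C(F)(F)C(F)(F)F)NCCCCCCCCCN[C@@H]1[C@H](O)[C@@H](O)[C@H](O)[C@H]2COC(=O)N21`: 65000 nM
compound 2 `O=C(CCC(F)(F)C(F)(F)C(F)(F)C(F)(F)C(F)(F)C(F)(F)C(F)(F)C(F)(F)F)NCCCCCCCCCN[C@@H]1[C@H](O)[C@@H](O)[C@H](O)[C@H]2COC(=O)N21`: 152000 nM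
compound 3 `O=C(CCC(F)(F)C(F)(F)C(F)(F)C(F)(F)C(F)(F)C(F)(F)F)NCCCCCCCCCN[C@@H]1[C@H](O)[C@@H](O)[C@@H](O)[C@H]2COC(=O)N21`: 56600 nM

Compound 3 stands level with compound 1 within the scatter, as a 1.1-fold lower number from compound 1 to compound 3 (0.06 log units; within the scatter) shows, and that pair comes with the fact that compounds 1 and 3 differ only in the configuration as drawn. Compound 2 carries the higher number of the three, well clear of compound 3 on their two values.

The next compound is compound 4 `O=C(CCC(F)(F)C(F)(F)C(F)(F)C(F)(F)C(F)(F)C(F)(F)C(F)(F)C(F)(F)F)NCCCCCCCCCN[C@@H]1[C@H](O)[C@@H](O)[C@@H](O)[C@H]2COC(=O)N21`. The change from compound 3 is 1,1,2,2,2-pentafluoroethyl in place of fluoro on a saturated chain carbon bound to two fluorine atoms and a saturated chain carbon. In words, it is 1,1,2,2,2-pentafluoroethyl in place of fluoro on a saturated chain carbon bound to two fluorine atoms and a saturated chain carbon.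

The same change has been measured once, as a 2.3-fold higher number from compound 1 to compound 2 (0.37 log units; beyond the scatter). Going by the values given here, that modest step is the only direct precedent, and it lies just beyond the scatter. The configuration difference gave no step beyond the scatter, so the same direction and a similar size are expected in this assay, though a single pair supports this only weakly.

The expected step is a 2.3-fold higher number from compound 3 to compound 4 (0.36 log units; beyond the scatter). For compound 4 the estimated value is 130000 nM, with an expected range of 70000 nM to 240000 nM.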

Compound 4, half-maximal effective concentration: 124000 nM
Compound 4: middle estimate off by 1.0-fold (0.02 log units), on the high side; low and high end bracket the measured number.
By their numbers in this assay, from the lowest: compounds 3, 1, 4 and 2 (each within the scatter of the next, the first and the last beyond it).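

In this assay, the replacement of fluoro by 1,1,2,2,2-pentafluoroethyl on a saturated chain carbon bound to two fluorine atoms and a saturated chain carbon now has a second reading, a 2.2-fold higher number from compound 3 to compound 4 (0.34 log units; beyond the scatter), so it no longer rests on a single pair and holds in both configurations shown: the same change on two cores in this assay, a 2.3-fold higher number (0.37 log units; beyond the scatter) from compound 1 to compound 2 and a 2.2-fold higher number (0.34 log units; beyond the scatter) from compound 3 to compound 4, 1.1-fold (0.03 log units) apart, within the scatter of two such steps. The configuration difference, earlier seen only as a 1.1-fold lower number from compound 1 to compound 3 (0.06 log units; within the scatter), also stays within the scatter with the 1,1,2,2,2-pentafluoroethyl extension in place, at a 1.2-fold lower number from compound 2 to compound 4 (0.09 log units; within the scatter): the fact that compounds 2 and 4 differ only in the configuration as drawn. Across these four compounds the chain change moves the number beyond the scatter and the configuration change does not, and no compound shown goes against this reading.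

The compounds shown leave open whether a longer perfluoroalkyl chain, or a plain alkyl chain without fluorine, would move the number in the same direction and by a similar amount. On these data alone, the other stereocentres of the shared core stay fixed throughout, so their bearing on this number also remains open.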